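Dihalophenyl hydrazone in a diaryl ether urea series

The source may hold more compounds than are shown below. What is called first, only, known or untested is meant among the compounds shown, and "the series" means these compounds.

Compounds measured so far:
Compound 1 `CN(C)CCn1cnnc1-c1cc(Oc2ccc(NC(=O)N/N=C/c3ccc(O)c(Br)c3)cc2F)ccn1` 1370 nM
Compound 2 `COc1ccc(/C=N/NC(=O)Nc2ccc(Oc3ccnc(-c4nncn4CCN(C)C)c3)c(F)c2)c(OC)c1OC` 6680 nM
Compound 3 `CN(C)CCn1cnnc1-c1cc(Oc2ccc(NC(=O)N/N=C/c3cccc(Br)c3)cc2F)ccn1` 970 nM

In a functional assay on A549 cells (Homo sapiens) for cytotoxicity, read by MTT assay, with a stated time of 72 h (a lower number here means a stronger inhibitor, a higher number a weaker inhibitor), compound 1 gives 1370 nM, the second highest of the three numbers. Its nearest neighbour is compound 3 with 970 nM, the step of a 1.4-fold lower number from compound 1 to compound 3 (0.15 log units; within the scatter) lying within the scatter; compound 2 with 6680 nM is furthest, with a 4.9-fold higher number from compound 1 to compound 2 (0.69 log units; beyond the scatter).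

Compound 4 `CN(C)CCn1cnnc1-c1cc(Oc2ccc(NC(=O)N/N=C/c3ccc(F)cc3Cl)cc2F)ccn1` is not yet measured. It differs from compound 1 by 2-chloro-4-fluorophenyl in place of 3-bromo-4-hydroxyphenyl on a carbon with a double bond to nitrogen. The relevant precedents are the loss of the hydroxy, a 1.4-fold lower number from compound 1 to compound 3 (0.15 log units; within the scatter), and the move to a trimethoxyphenyl, a 6.9-fold lower number from compound 2 to compound 3 (0.84 log units; beyond the scatter), which shows that a phenyl with halogens only sits at the lower end. For a halogen-bearing phenyl without oxygen the expected step is therefore estimated at about a 1.1-fold lower number from compound 1 to compound 4 (0.06 log units; within the scatter) in this assay, within the scatter. Compound 4 is expected to give 1200 nM, with a range from 500 nM to 3000 nM.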

Compound 4, half-maximal inhibitory concentration: 1120 nM
Compound 4: middle estimate off by 1.1-fold (0.03 log units), on the high side, and the stated range covers the measured number.
By their numbers in this assay, from the lowest: compounds 3, 4 and 1 (each within the scatter of the next); then compound 2.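

In this assay, the 2-chloro-4-fluorophenyl group, with 0 hydrogen-bond donors and 0 acceptors, stays within the scatter of both the 3-bromo-4-hydroxyphenyl group (a 1.2-fold lower number from compound 1 to compound 4 (0.09 log units; within the scatter)) and the 3-bromophenyl group (a 1.2-fold higher number from compound 3 to compound 4 (0.06 log units; within the scatter)), so this position accepts a different halogen pair without a readable change. The 2,3,4-trimethoxyphenyl group now stands apart from all three other compounds, including this one (a 6.0-fold lower number from compound 2 to compound 4 (0.78 log units; beyond the scatter)). No measurement is available to explain these steps. Going by these compounds, whether a single methoxy group would match compound 2 or the halogen-bearing compounds remains open, as does the effect of an amine or a carboxylic acid on this phenyl ring.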